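The source may hold more compounds than are shown below. What is called first, only, known or untested is meant among the compounds shown, and "the series" means these compounds.

Measured compounds:
- compound 1 `Cc1cc(NCCN(C)C)nc2ccc(NC(=O)c3ccc(Cl)c(Cl)c3)cc12`: 2550 nM
- compound 2 `CCN1CCN(c2cc(C)c3cc(NC(=O)c4ccccc4C)ccc3n2)CC1`: 10900 nM
- compound 3 `CCN1CCN(c2cc(C)c3cc(NC(=O)c4ccco4)ccc3n2)CC1`: 41200 nM

In a functional assay on MCF7 cells (Homo sapiens) for antiproliferative activity, read by MTT assay, with a stated time of 72 h (a lower number here means a stronger inhibitor, a higher number a weaker inhibitor), compound 1 gives the lowest of the three numbers; compound 2 sits a step higher and compound 3 higher still. Going by the values given here, the only single-point step measured, a 3.8-fold higher number from compound 2 to compound 3 (0.58 log units; beyond the scatter), concerns the group on the carbonyl carbon, a different part of the shared core. Compound 4 `CCNc1cc(C)c2cc(NC(=O)c3ccc(Cl)c(Cl)c3)ccc2n1` differs from compound 1 elsewhere: hydrogen in place of dimethylamino on a saturated chain carbon, two bonds along the chain from a nitrogen on an aromatic ring. Among the compounds with values here, no measured step bears on this change, so nothing in the data fixes its direction or size. The expectation is a step of a 2.0-fold higher number from compound 1 to compound 4 (0.29 log units; within the scatter), likely modest, and compound 4 is estimated to give 5000 nM, within a range from 1500 nM to 16000 nM.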

Compound 4, half-maximal inhibitory concentration: 48600 nM
Beside the measured number, compound 4's estimate is 9.7-fold (0.99 log units) below it, outside the stated range (above it).
By their numbers in this assay, from the lowest: compound 1; then compound 2; then compounds 3 and 4 (each within the scatter of the next).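

In this assay, the step of a 19-fold higher number from compound 1 to compound 4 (1.28 log units; beyond the scatter) shows that this one change on the saturated chain carbon, hydrogen in place of dimethylamino, is enough to make a large difference. Going by these compounds alone, until now, the only step measured concerned the group on the carbonyl carbon, so this is the first sign that the chain matters too. No evidence here bears on why the number moves this far. The compounds shown leave open whether another amine, such as pyrrolidine or morpholine, could stand in place of dimethylamino, and what a hydroxyl group or a carboxylic acid there would do. Going by these compounds, a longer chain carrying dimethylamino also remains open.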